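The source may report more compounds than this note shows. Statements on the series, on what has been measured and on what is new or still open speak of the compounds shown alone.

Compound 1 `CCOc1c(NC)cnn(C)c1=O` gives 4.5% in a functional assay on the whole organism (strain Wistar) for inhibition, with Rattus norvegicus as the target, read by paw edema, with stated times of 30 min and 3 h, at a dose of 50 mg/kg by the oral route (a higher number here means a stronger effect of the compound at the dose given, a lower number a weaker effect), the second highest of three numbers. Compound 2 `CCCNc1cnn(C)c(=O)c1OCC` gives 8% and compound 3 `CCOc1c(N2CCCCC2)cnn(C)c1=O` gives -5.4% in this assay; both of these lie within the scatter of compound 1. Compound 4 `CCOc1c(N2CCCC2)cnn(C)c1=O` differs from compound 1 by pyrrolidin-1-yl in place of methylamino on an aromatic carbon. Going by the values given here, the one measured step, a number 3.5 percentage points higher from compound 1 to compound 2 (within the scatter), alters the chain on the amine nitrogen and moved nothing beyond the scatter. Compound 3 carries a ring on that nitrogen, as compound 4 does, and its value differs from compound 1 by less than the scatter. For compound 4 no step beyond the scatter is therefore expected in this assay. The expected step is a number 6.5 percentage points lower from compound 1 to compound 4 (within the scatter). Compound 4 is estimated at -2%, range -14% to 10%.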

Compound 4, a percentage reported as inhibition, in the whole organism at one dose (the size of the read-out at that dose, not a potency): -2.3%
Estimate against measurement, compound 4: 0.3 percentage points above; low and high end bracket the measured number.
By their numbers in this assay, from the lowest: compounds 3, 4, 1 and 2 (each within the scatter of the next, the first and the last beyond it).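

With pyrrolidin-1-yl in place of methylamino on this aromatic carbon, this assay shows a number 6.8 percentage points lower from compound 1 to compound 4 (within the scatter) and so no separable change. Going by these compounds alone, with pyrrolidin-1-yl in place of propylamino, it shows a number 10.3 percentage points lower from compound 2 to compound 4 (beyond the scatter) as the only step at this position that passes the scatter, so the separation from an open chain holds against one of the two chains, and modestly. No measurement available bears on the reason for these numbers.

On these data alone, whether dimethylamino or piperazin-1-yl on this carbon would give a number beyond the scatter of compound 1 remains open. As far as these compounds go, the effect of a longer chain on the amine nitrogen, such as pentylamino, also remains open.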